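Chloro Gives Way to Methyl in Compound 3

A few compounds are considered here, and "the series" means these few. Any claim that something is new, unique, unknown or untested is made for them only; others in the source may bear on it.

In a functional assay on HT-29 cells (Homo sapiens) for inhibition, read by sulforhodamine B assay, with a stated time of 48 h (a lower number here means a stronger inhibitor of growth, a higher number a weaker inhibitor of growth), compound 1 `CC(C)(C)NCc1c(C(=O)O)nn(-c2ccccc2)c1-c1ccc(Cl)cc1` gives 353000 nM as a measured number. Compound 2 `CC(C)(C)NCc1c(C(=O)O)nn(-c2ccc(Cl)cc2)c1-c1ccc(Cl)cc1` stands at > 599000 nM which is a limit and not a number. Compound 3 `Cc1ccc(-c2c(CNC(C)(C)C)c(C(=O)O)nn2-c2ccc(Cl)cc2)cc1` departs from it by methyl in place of chloro on an aromatic carbon with methyl in place of chloro on an aromatic carbon. Going by the values given here, the one measured step of an at least 1.6-fold higher number from compound 1 to compound 2 (0.22 log units; that floor lies within the scatter) brings chloro in place of hydrogen elsewhere and leaves the 4-chlorophenyl group untouched, so it bears only weakly here. Accordingly an at least 1.0-fold lower number from compound 2 to compound 3 (0.03 log units; that floor lies within the scatter) is expected to stay within the scatter with no direction favoured. The estimate for compound 3 is 550000 nM with an expected range from 280000 nM to 900000 nM in this assay and the result may again be only a limit.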

Compound 3, concentration for 50% growth inhibition: > 629000 nM
Compound 3: only a limit was reported; the forecaster's own chance of this, stated with the estimate: 55%; middle value at least 1.1-fold (0.05 log units) away from the limit.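

In this assay compound 3 gives > 629000 nM, a limit and not a number. Going by these compounds alone, compound 2 is also only a limit, so no step between compound 2 and compound 3 can be read. From the compounds shown here alone, whether 4-chlorophenyl or 4-methylphenyl gives the stronger inhibitor of growth stays open.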